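The source may report more compounds than this note shows. Statements on the series, on what has been measured and on what is new or still open speak of the compounds shown alone.

Three compounds have been measured in a functional assay on HeLa cells (Homo sapiens) for cytotoxicity, read by XTT assay, with a stated time of 24 h; a lower number here means a stronger inhibitor, a higher number a weaker inhibitor:

Compound 1, `Cc1cc(Cl)c2c(c1O)C(=O)C=CC2=O`, gives 10100 nM.
Compound 2, `CCOc1cc(C)cc2c1C(=O)C=CC2=O`, gives 29700 nM.
Compound 3, `CCOc1cc(C)c(Cl)c2c1C(=O)C=CC2=O`, gives 19000 nM.

Compound 1 gives the lowest of the three numbers. Its nearest neighbour is compound 3, whose value lies within the scatter of compound 1, so no order can be read between those two; compound 2 stands beyond the scatter from compound 1. The difference between the core of compound 1 and the core of compound 3 is not broken down here.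

One structural change occurs twice among these compounds. Between compound 3 and compound 2 it is hydrogen in place of chloro on an aromatic carbon, and it made a step of a 1.6-fold higher number from compound 3 to compound 2 (0.19 log units; within the scatter) in this assay. The unmeasured compound 4, `Cc1ccc2c(c1O)C(=O)C=CC2=O`, is related to compound 1 by hydrogen in place of chloro on an aromatic carbon. The surroundings are not identical: in compound 3 the carbon carrying the chloro is ortho to a methyl group and para to an ethoxy group, whereas in compound 1 it is meta to a methyl group and para to a hydroxy group. It is therefore the same kind of change, not the same change.

Resting on the step of a 1.6-fold higher number from compound 3 to compound 2 (0.19 log units; within the scatter), compound 4 is expected to differ from compound 1 by a 1.5-fold higher number from compound 1 to compound 4 (0.17 log units; within the scatter) in this assay. Compound 4 is estimated at 15000 nM, with a likely range from 6000 nM to 35000 nM.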

Compound 4, half-maximal inhibitory concentration: 16400 nM
Estimate against measurement, compound 4: 1.1-fold (0.04 log units) below; the measured number falls inside the stated range.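

In this assay the replacement of chloro by hydrogen on the core of compound 1 gives a step that stays within the scatter (a 1.6-fold higher number from compound 1 to compound 4 (0.21 log units; within the scatter)), so on this core, as on the core of compound 3, no order can be read between the chloro compound and its hydrogen partner. What carries from one core to the other is therefore only the small size of the step; with both steps inside the scatter, the agreement does not show that chloro raises or lowers the number on either core, and two cores say nothing about any other core in this series. Set side by side, the two steps read as follows: the same change on two cores in this assay, a 1.6-fold higher number (0.19 log units; within the scatter) from compound 3 to compound 2 and a 1.6-fold higher number (0.21 log units; within the scatter) from compound 1 to compound 4, 1.0-fold (0.02 log units) apart, within the scatter of two such steps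

The compounds shown hold only chloro or hydrogen on this aromatic carbon, so it remains open whether a bromine atom, a methoxy group or an amine there would move the number beyond the scatter. They also carry only a hydroxy or an ethoxy group on the other side of the ring, which leaves open how the step would read with a longer chain or a carboxylic acid in that place.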